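Shifting One Hydroxyl Group Where Both Measured Values Are Limits

This account rests on a few compounds, and the source may have more. Where it says the series, first, only, none or still open, it means among the compounds named here.

compound 1 `Oc1ccccc1-c1cc(-c2ccccc2F)cc(-c2ccccc2O)n1`: > 50000 nM
compound 2 `Oc1ccccc1-c1cc(-c2ccc(F)cc2)cc(-c2ccccc2O)n1`: > 50000 nM

In a functional assay on DU-145 cells (Homo sapiens) for inhibition (a lower number here means a stronger inhibitor, a higher number a weaker inhibitor), compound 1 gives > 50000 nM, which is a limit of the assay rather than a number. Compound 2 likewise gives > 50000 nM, again only a limit. Going by the values given here, the single measured step, a step that the two limits leave unreadable from compound 1 to compound 2, cannot be read because of the limit of > 50000 nM in this assay, at which 2 of the 2 values shown sit. Compound 1 therefore stands at the limit, with no number to place it more finely.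

Compound 3 is `Oc1cccc(-c2cc(-c3ccccc3F)cc(-c3ccccc3O)n2)c1`. It differs from compound 1 in one place: 3-hydroxyphenyl in place of 2-hydroxyphenyl on an aromatic carbon. Among the compounds with values here, no measured step involves this hydroxyl position, so nothing bears directly on it; the only measured change, the fluorine shift, gave no readable step. Compound 3 is expected to give 50000 nM, within 15000 nM to 150000 nM. This estimate corresponds to an expected step of a number no higher from compound 1 to compound 3 (the limit leaves the size open) that most likely stays hidden behind the limit.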

Compound 3, half-maximal inhibitory concentration: 35600 nM
Estimate against measurement, compound 3: 1.4-fold (0.15 log units) above; measured number inside the range.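

In this assay, going by these compounds alone, compound 3, which carries 3-hydroxyphenyl in place of 2-hydroxyphenyl, gives 35600 nM, the first value in this set that is a number and not a limit. Within the data shown here, the step is an at least 1.4-fold lower number from compound 1 to compound 3 (0.14 log units; that floor lies within the scatter), so this hydroxyl position is the first place where a change brings a compound into the readable range, although that floor alone does not separate the two compounds beyond the usual scatter. The true size of the step cannot be read because compound 1 has no number: the limit of > 50000 nM in this assay, at which 2 of the 3 values shown sit.

Still open, going by these compounds, is whether the remaining 2-hydroxyphenyl group responds to the same shift, and whether the 3-hydroxyphenyl result holds alongside the 4-fluorophenyl group of compound 2. Also open, on these data alone, is what an amine or a methoxy group would do in place of this hydroxyl.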